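The compounds below may be only part of what the source reports. "The series", "measured", "known", "first", "only" and "open" are said of these compounds alone.

Measured compounds:

compound 1, `CCNCC1CCN(c2c(F)cc3c(=O)c(C(=O)O)cn(CC)c3c2F)C1`, 160 ug/mL
compound 2, `CCNCC1CCN(c2cc3c(cc2F)c(=O)c(C(=O)O)cn3CC)C1`, 310 ug/mL
compound 3, `O=C(O)c1cn(C2CC2)c2cc(N3CCCC3)c(F)cc2c1=O`, 38 ug/mL

All three numbers come from a functional assay on V79 cells (Cricetulus griseus) for cytotoxicity, read by colony formation; on this read-out lower numbers stand for stronger inhibition and higher numbers for weaker inhibition. Compound 1 and compound 2 share a core and differ in one place: fluoro in place of hydrogen on an aromatic carbon. The step that this change made is a 1.9-fold lower number from compound 2 to compound 1 (0.29 log units; within the scatter), so the two values cannot be told apart by this kind of measurement. Compound 3 has a different core; the difference between the two cores is not broken down here. What its value shows is that compound 3 gives the lowest number of the three, and its gap to compound 1 and to compound 2 lies beyond the scatter.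

Compound 4, `O=C(O)c1cn(C2CC2)c2c(F)c(N3CCCC3)c(F)cc2c1=O`, has not been measured yet. It differs from compound 3 in one place: fluoro in place of hydrogen on an aromatic carbon. Among the compounds with values here, this is the same kind of change as the one from compound 2 to compound 1, and the change sits on the same kind of ring in both cases, ortho to a fused ring, meta to a fluoro group and meta to a fused ring. What differs around the place is the neighbouring group: in compound 1 the new fluoro is ortho to a 3-((ethylamino)methyl)pyrrolidin-1-yl group, whereas in compound 4 it is ortho to a pyrrolidin-1-yl group.

Since the earlier step of this kind, a 1.9-fold lower number from compound 2 to compound 1 (0.29 log units; within the scatter), stayed within the scatter, a step of similar size is expected from compound 3 to compound 4, namely a 1.4-fold lower number from compound 3 to compound 4 (0.13 log units; within the scatter). Compound 4 is therefore expected to give about 28 ug/mL in this assay, most likely between 12 ug/mL and 65 ug/mL.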

Compound 4, half-maximal inhibitory concentration: 120 ug/mL
Estimate against measurement, compound 4: 4.3-fold (0.63 log units) below; the measured number lies above the stated range.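

In this assay, putting a fluoro in place of hydrogen on the aromatic carbon ortho to a pyrrolidin-1-yl group gave a 3.2-fold higher number from compound 3 to compound 4 (0.50 log units; beyond the scatter). Set beside the earlier case, the same change does not behave alike on the two cores: the same change on two cores in this assay, a 1.9-fold lower number (0.29 log units; within the scatter) from compound 2 to compound 1 and a 3.2-fold higher number (0.50 log units; beyond the scatter) from compound 3 to compound 4, 6.1-fold (0.79 log units) apart, beyond the scatter of two such steps

So, in these two pairs, the outcome of this change on one core is a poor guide to its outcome on the other, but two pairs do not make a rule for the series, and they do not show which structural difference between the pairs accounts for the gap.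

On these data alone, the pairs differ both in the ethyl or cyclopropyl group and in the 3-((ethylamino)methyl)pyrrolidin-1-yl or pyrrolidin-1-yl group, so it remains open which of these matters, and a compound combining the cyclopropyl group with the 3-((ethylamino)methyl)pyrrolidin-1-yl group, tested with and without the new fluoro, could help to separate them. Also open is how a chloro or a methoxy group on the same aromatic carbon would read in this assay, since every pair shown compares only hydrogen with fluoro.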